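A Hydroxymethyl Triazole Takes the Silicon Group's Place

This account rests on a few compounds, and the source may have more. Where it says the series, first, only, none or still open, it means among the compounds named here.

Of the compounds shown here, three sharing one core have been tested in a functional assay on MCF7 cells (Homo sapiens) for antiproliferative activity, read by MTT assay, with a stated time of 48 h; a higher number here means a weaker inhibitor, a lower number a stronger inhibitor. In this test, compound 1 `COC/C1=C/C[C@](C)(CCC=C(C)C)/C=C/[C@@H](OC(=O)C=C(C)C)[C@](C)(O)/C=C/C1=O` gives 4130 nM. Compound 2 `CC(C)=CCC[C@]1(C)/C=C/[C@@H](OC(=O)C=C(C)C)[C@](C)(O)/C=C/C(=O)/C(CN(C)C)=C\C1` gives 690 nM, and compound 3 `CC[Si](CC)(CC)C/C1=C/C[C@](C)(CCC=C(C)C)/C=C/[C@@H](OC(=O)C=C(C)C)[C@](C)(O)/C=C/C1=O` gives 3150 nM. Compound 3 cannot be told apart from compound 1, as a 1.3-fold lower number from compound 1 to compound 3 (0.12 log units; within the scatter) shows. It stands clearly weaker than compound 2, with a 4.6-fold higher number from compound 2 to compound 3 (0.66 log units; beyond the scatter).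

Compound 4 `CC(C)=CCC[C@]1(C)/C=C/[C@@H](OC(=O)C=C(C)C)[C@](C)(O)/C=C/C(=O)/C(Cn2cc(CO)nn2)=C\C1` keeps the core of compound 3 and changes one group, on a saturated chain carbon bound to a double-bonded ring carbon: a group of 7 heavy atoms (3 carbon, 3 nitrogen, 1 oxygen; one five-membered aromatic ring with 3 hetero atoms) in place of a group of 7 heavy atoms (6 carbon, 1 silicon; no ring), on a saturated chain carbon bound to a double-bonded ring carbon. The group that enters is 4-(hydroxymethyl)-1H-1,2,3-triazol-1-yl.

Within the data shown here, all the measured steps were made at this same place, so they set the scale. They range from no visible change to the modest 6.0-fold lower number from compound 1 to compound 2 (0.78 log units; beyond the scatter). Among the measured compounds shown here, none of the measured groups has a ring, so no direct comparison for the triazole exists. For the measured compounds named here, the dimethylamino group of compound 2 is the only measured group containing nitrogen, and the entering group contains nitrogen too, which gives a weak lean towards a lower number. The estimated step is small, a 1.6-fold lower number from compound 3 to compound 4 (0.20 log units; within the scatter). For compound 4 the expected value is 2000 nM, with an estimated range from 650 nM to 6000 nM.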

Compound 4, half-maximal inhibitory concentration: 2930 nM
Beside the measured number, compound 4's estimate is 1.5-fold (0.17 log units) below it; the measured number falls inside the stated range.
By their numbers in this assay, from the lowest: compound 2; then compounds 4, 3 and 1 (each within the scatter of the next).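

In this assay, the step is a 1.1-fold lower number from compound 3 to compound 4 (0.03 log units; within the scatter), so at this position a silicon-bearing group with no ring and the 4-(hydroxymethyl)-1H-1,2,3-triazol-1-yl group, which has the same heavy-atom count but carries a five-membered aromatic ring and hydrogen-bond donor and acceptors, cannot be told apart. Nitrogen in the entering group is not enough to match compound 2, since the step is a 4.2-fold higher number from compound 2 to compound 4 (0.63 log units; beyond the scatter), and compound 4 therefore goes against any simple link between nitrogen and a lower number. With a 1.4-fold lower number from compound 1 to compound 4 (0.15 log units; within the scatter), the methoxy, silicon-bearing and triazole compounds form one group within the scatter, and among these four compounds only the dimethylamino compound stands apart.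

Still open, going by these compounds, is whether compound 2's standing belongs to dimethylamino alone or would be shared by other amines, such as a pyrrolidine or a simple primary amine, and how a carboxylic acid would compare at this position. The data shown offer no measurement that accounts for the dimethylamino group's separate standing.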